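Two Hydroxyethyl Groups in Place of One Hydroxybutyl

The source may report more compounds than this note shows. Statements on the series, on what has been measured and on what is new or still open speak of the compounds shown alone.

In an assay on isolated protein for inhibition of alkaline phosphatase, tissue-nonspecific isozyme (Homo sapiens) (on this read-out lower numbers stand for stronger inhibition and higher numbers for weaker inhibition), compound 2 `O=C(NCCCCO)c1cc(-c2ccc(Cl)cc2Cl)n[nH]1` gives 35 nM, and compound 1 `CC(C)NC(=O)c1cc(-c2ccc(Cl)cc2Cl)n[nH]1` gives 51 nM; the two numbers lie within the scatter of each other, as a 1.5-fold lower number from compound 1 to compound 2 (0.16 log units; within the scatter) shows. Compound 3 `O=C(c1cc(-c2ccc(Cl)cc2Cl)n[nH]1)N(CCO)CCO` carries bis(2-hydroxyethyl)amino in place of (4-hydroxybutyl)amino on a carbonyl carbon. Among the compounds with values here, the only measured step, on the same amide-type nitrogen, stayed within the scatter, so the change to compound 3 is expected to bring little beyond it in this assay, at most a small rise, since no measured compound lacks a hydrogen on that nitrogen. Compound 3 is therefore expected at 60 nM, between 20 nM and 180 nM, a step of a 1.7-fold higher number from compound 2 to compound 3 (0.23 log units; within the scatter).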

Compound 3, half-maximal inhibitory concentration: 47 nM
Estimate against measurement, compound 3: 1.3-fold (0.11 log units) above; the range from low to high includes it.
By their numbers in this assay, from the lowest: compounds 2, 3 and 1 (each within the scatter of the next).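

Compound 3 is the first compound shown with no hydrogen on the amide-type nitrogen, and in this assay the replacement stays within the scatter, with a 1.3-fold higher number from compound 2 to compound 3 (0.13 log units; within the scatter) and a 1.1-fold lower number from compound 1 to compound 3 (0.04 log units; within the scatter) as its steps. This position on a carbonyl carbon therefore takes two hydroxyethyl chains on that nitrogen without a change this read-out can resolve. No evidence is available that bears on this result.

The compounds shown leave open whether a terminal amine or carboxylic acid, or a longer chain, would give a step beyond the scatter.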